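This account rests on a few compounds, and the source may have more. Where it says the series, first, only, none or still open, it means among the compounds named here.

Measured so far:
compound 1, `CSc1cccc(-c2cc(NC(=O)C(Cl)Cl)cc(-c3cccc(SC)c3)c2)c1`: > 30000 nM
compound 2, `Nc1cccc(-c2cccc(NC(=O)C(Cl)Cl)c2)c1`: 26100 nM
compound 3, `CC(C)c1ccc(-c2cc(NC(=O)C(Cl)Cl)cc(-c3ccc(C(C)C)cc3)c2)cc1`: > 30000 nM

In a functional assay on KB 3-1 cells (Homo sapiens) for cytotoxicity, read by MTT assay, with a stated time of 68 h (on this read-out higher numbers stand for weaker inhibition and lower numbers for stronger inhibition), compound 1 reaches only a limit, > 30000 nM. Compound 3 likewise gives a limit, > 30000 nM. Among the compounds with values here, compound 2 is the only member with a number, 26100 nM, and so the single measured anchor of the series. The other two values are limits only, namely (the limit of > 30000 nM in this assay, at which 2 of the 3 values shown sit). Within the data shown here, no pair of measured compounds differs in a single place, so no measured step is available.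

Compound 4, `O=C(Nc1cccc(-c2cccc(C(F)(F)F)c2)c1)C(Cl)Cl`, is not yet measured in this assay. It differs from compound 2 as trifluoromethyl in place of amino on an aromatic carbon. Among the measured compounds shown here, no measured pair connects these two groups, so the size of the step cannot be drawn from data. The number for compound 4 in this assay is expected to stay near that of compound 2, with the step of a 1.1-fold higher number from compound 2 to compound 4 (0.06 log units; within the scatter) expected to lie within or only slightly beyond the scatter, if anything toward weaker inhibition. Compound 4 is therefore estimated at 30000 nM, between 12000 nM and 80000 nM, with a fair chance that only a limit is returned.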

Compound 4, half-maximal inhibitory concentration: > 50000 nM
Compound 4 gave a limit, no number; the forecaster's own chance of this, stated with the estimate: 50%; at least 1.6-fold (0.22 log units) between middle value and limit.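

Within the data shown here, the step of an at least 1.9-fold higher number from compound 2 to compound 4 (0.28 log units; that floor lies within the scatter) is the only single-place comparison, read in this assay on an aromatic carbon, meta to a large group. On these data alone, compound 4 gives a limit (> 50000 nM) and not a number, so the step is a floor and its true size stays unknown. It does show that trifluoromethyl in place of amino brings no stronger inhibition at this position, although a loss beyond the scatter is not established either.

As far as these compounds go, whether any group here can give stronger inhibition than amino stays open, for instance a carboxylic acid, a nitrile or a methoxy group. Also open, from the compounds shown here alone, is how the same exchange would read on a core that gives a clear number well inside the range of the assay.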